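From sulfamoyl to amino on the shared core

This account rests on a few compounds, and the source may have more. Where it says the series, first, only, none or still open, it means among the compounds named here.

Measured in an ADME assay on microsomes from liver (Mus musculus) for metabolic stability, read by LC-MS, using NADPH, with a stated time of 30 min, tested at 0.1 uM; a lower number here means that less of the compound is left, a higher number that more of the compound is left:
Compound 1 `O=S(=O)(NCC1COC1)c1cccc(-c2ccc3nccc(-c4ccncc4)c3n2)c1`: 19%
Compound 2 `C[C@@H]1CN(S(=O)(=O)c2cccc(-c3ccc4nccc(-c5ccncc5)c4n3)c2)C[C@H](C)N1`: 33%

Of these two, compound 1 holds the lower number, and compound 2 is its nearest neighbour. Going by the values given here, the only measured step, a number 14 percentage points higher from compound 1 to compound 2 (beyond the scatter), exchanges ((oxetan-3-yl)methyl)amino for 3,5-dimethylpiperazin-1-yl on a sulfonyl sulfur.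

Compound 3 `Nc1cccc(-c2ccc3nccc(-c4ccncc4)c3n2)c1` has not yet been measured. Its difference from compound 1 is of another kind: amino in place of ((oxetan-3-yl)methyl)sulfamoyl on an aromatic carbon. The sulfonyl group is therefore lost, whereas it stays in the measured step, so a number 14 percentage points higher from compound 1 to compound 2 (beyond the scatter) bears on this change only loosely. It shows that a change in this part of the structure can move the number modestly. Among the compounds with values here, no measured compound carries the amino group, and the direction remains open. The expected step is small, a number 5 percentage points higher from compound 1 to compound 3 (within the scatter). In this assay the estimated value for compound 3 is 24%, with an expected range from 8% to 48%.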

Compound 3, percent of the compound remaining: 54%
Estimate against measurement, compound 3: 30 percentage points below; the whole stated range lies below it.
By their numbers in this assay, from the lowest: compound 1; then compound 2; then compound 3.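

In this assay, the change on this aromatic carbon, meta to a large group, goes further than the exchange on the sulfonyl sulfur did: the sulfonyl group itself is gone, and amino in place of ((oxetan-3-yl)methyl)sulfamoyl gives a number 35 percentage points higher from compound 1 to compound 3 (beyond the scatter). Amino in place of (3,5-dimethylpiperazin-1-yl)sulfonyl points the same way, with a number 21 percentage points higher from compound 2 to compound 3 (beyond the scatter), so compound 3 stands above both sulfonyl-bearing compounds, and the group with 1 heavy atom gives a higher number here than the group with 9 heavy atoms that it replaces in compound 1. Nothing available here accounts for this rise.

The compounds shown do not separate the removal of the sulfonyl group from the presence of the amino group, so it remains open whether a hydroxyl, a methylamino or an acetamide group on the same aromatic carbon would give a number like that of compound 3. As far as these compounds go, it also remains open whether a plain sulfamoyl group, with no chain on its nitrogen, would stand nearer compound 1 or compound 3.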